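Working notes: from compound 1 to compound 4

The source may report more compounds than this note shows. Statements on the series, on what has been measured and on what is new or still open speak of the compounds shown alone.

Compound 1 `COc1ccc2cc([C@H](C)c3nnc(SCc4ccc(C)cc4)n3-c3ccc(F)cc3)ccc2c1` gives 44300 nM in a functional assay on DU-145 cells (Homo sapiens) for cytotoxicity, read by MTT assay (a lower number here means a stronger inhibitor, a higher number a weaker inhibitor), the higher of the two actual numbers in this small set. Compound 3 `COc1ccc2cc([C@H](C)c3nnc(SCc4ccc(C)cc4)n3-c3ccc(Cl)cc3)ccc2c1` gives 18800 nM in this assay. Compound 2 `COc1ccc2cc([C@H](C)c3nnc(SCc4c(Cl)cccc4Cl)n3-c3cccc(Cl)c3)ccc2c1` is reported only as a limit, <= 400000 nM, and offers no single-place comparison with compound 1.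

The next structure is compound 4 `COc1cccc(CSc2nnc([C@@H](C)c3ccc4cc(OC)ccc4c3)n2-c2ccc(F)cc2)c1`. Its change from compound 1 is 3-methoxyphenyl in place of 4-methylphenyl on a saturated chain carbon bound to a sulfur. In words, 3-methoxyphenyl stands in place of 4-methylphenyl on a saturated chain carbon bound to a sulfur.

Among the compounds with values here, no measured step covers this place. Within the data shown here, the only measured single-place step is chloro in place of fluoro on an aromatic carbon, which gives a 2.4-fold lower number from compound 1 to compound 3 (0.37 log units; beyond the scatter). That modest step lies beyond the scatter, but it concerns a different part of the structure, so it serves only as a rough guide to size and says nothing about direction here.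

With no measured support for either direction, no shift beyond the scatter is expected in this assay. The estimated change is a 1.1-fold lower number from compound 1 to compound 4 (0.04 log units; within the scatter), and the uncertainty remains wide. For compound 4 the expected value is 40000 nM, with an estimated range of 13000 nM to 120000 nM.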

Compound 4, half-maximal inhibitory concentration: 19200 nM
For compound 4 the middle estimate is 2.1-fold (0.32 log units) above the measured one; the range from low to high includes it.
By their numbers in this assay, from the lowest: compounds 3 and 4 (each within the scatter of the next); then compound 1.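

The arm on the saturated chain carbon bound to a sulfur now proves open to change in this assay: 3-methoxyphenyl in place of 4-methylphenyl gives a 2.3-fold lower number from compound 1 to compound 4 (0.36 log units; beyond the scatter). Within the data shown here, until this result, the only single-place step on compound 1 was on the other side of the structure, chloro in place of fluoro on an aromatic carbon, with a 2.4-fold lower number from compound 1 to compound 3 (0.37 log units; beyond the scatter), so the number now responds to a change in each of two separate parts of compound 1, with both steps modest and beyond the scatter. Nothing at hand speaks to the reason for the new step.

The step joins a change of group, methyl to methoxy, with a change of ring position, and a 4-methoxyphenyl or 3-methylphenyl group on this carbon would be needed to tell these two apart. Also open, on these data alone, are how an amine or a carboxylic acid on this ring would read, and whether 3-methoxyphenyl gives a similar step with chloro in place of fluoro.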